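The compounds below may be only part of what the source reports. "The series", "measured", "known", "first", "only" and "open" are said of these compounds alone.

Going by the values given here, in an ADME assay on PA-1 cells (Homo sapiens) for cytotoxicity, read by MTT assay, with a stated time of 72 h (on this read-out lower numbers stand for stronger inhibition and higher numbers for weaker inhibition), compound 1 `COc1ccc(OC)c(C2=C(c3cc(OC)c(OC)c(OC)c3)C(=O)CC2O[SiH2]C(C)(C)C)c1` gives 17 ug/mL, the only numerical value so far. Compound 2 `COc1ccc(C2=C(c3cc(OC)c(OC)c(OC)c3)C(=O)C(O)C2)cc1Cl` gives > 100 ug/mL, which is a limit of the assay and not a number. Compound 3 `COc1cc(C2=C(c3ccccc3)C(O[SiH2]C(C)(C)C)CC2=O)cc(OC)c1OC` differs from compound 1 as follows: phenyl in place of 2,5-dimethoxyphenyl on a double-bonded ring carbon, with phenyl in place of 2,5-dimethoxyphenyl on a double-bonded ring carbon. Among the compounds with values here, no measured pair shows this change, so the expectation is loose. A modest weakening in this assay is expected, with the estimated step of a 1.5-fold higher number from compound 1 to compound 3 (0.17 log units; within the scatter). The estimated value for compound 3 is 25 ug/mL, with an expected range of 9 ug/mL to 70 ug/mL.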

Compound 3, half-maximal inhibitory concentration: > 100 ug/mL
Compound 3 ended at the assay's limit; the forecaster's own chance of this, stated with the estimate: 15%; at least 4.0-fold (0.60 log units) between middle value and limit.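

Phenyl in place of 2,5-dimethoxyphenyl on a double-bonded ring carbon gives, in this assay, an at least 5.8-fold higher number from compound 1 to compound 3 (0.76 log units; beyond the scatter), the first readable step in the series. This position therefore matters: removing both methoxy groups of compound 1 takes the value out of the measurable range. Going by these compounds, the value of compound 3 is a limit and not a number, so the true size of the step remains unknown: the limit of > 100 ug/mL in this assay, at which 2 of the 3 values shown sit.

On these data alone, whether a single methoxy group would suffice remains open. So does the outcome with a 2,5-dihydroxyphenyl or an aminophenyl group in the same place.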